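This account rests on a few compounds, and the source may have more. Where it says the series, first, only, none or still open, it means among the compounds named here.

Compound 2 `COc1ccc(C(=O)/C=C/c2cc(-c3cc(OC)c(OC)c(OC)c3)n[nH]2)cc1OC` holds the lowest of the two numbers in a functional assay on MDA-MB-435 cells (Homo sapiens) for cytotoxicity, read by sulforhodamine B assay, with a stated time of 48 h, tested at 10 uM (a lower number here means a stronger effect, a higher number a weaker effect of the compound at the concentration tested), giving -92%; compound 1 `COc1cc(-c2cc(/C=C/C(=O)c3ccc(Cl)c(Cl)c3)[nH]n2)cc(OC)c1OC` gives 37% in this assay. Compound 3 `COc1cc(-c2cc(/C=C/C(=O)c3ccc(F)c(F)c3)[nH]n2)cc(OC)c1OC` differs from compound 2 by 3,4-difluorophenyl in place of 3,4-dimethoxyphenyl on a carbonyl carbon. Within the data shown here, the one step that bears on this is a number 129 percentage points lower from compound 1 to compound 2 (beyond the scatter), which ran in the opposite sense, from 3,4-dichlorophenyl to 3,4-dimethoxyphenyl on the carbonyl carbon. Returning to a halogenated ring is therefore expected to raise the number by a large step, though 3,4-difluorophenyl is not 3,4-dichlorophenyl, so a number 97 percentage points higher from compound 2 to compound 3 (beyond the scatter) is estimated to fall short of a full return. Compound 3 is expected at 5%, within -60% to 55%.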

Compound 3, a percentage reported as activity, at one concentration (the size of the read-out at that concentration, not a potency): 5%
Compound 3: the middle estimate sits on the measured number at the digits printed; the measured number falls inside the stated range.
By their numbers in this assay, from the lowest: compound 2; then compound 3; then compound 1.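

The ring on the carbonyl carbon separates even two halogen patterns: in this assay there is a step (a number 32 percentage points lower from compound 1 to compound 3 (beyond the scatter)), so 3,4-difluorophenyl and 3,4-dichlorophenyl are not interchangeable here. The larger step (a number 97 percentage points higher from compound 2 to compound 3 (beyond the scatter)) leaves 3,4-dimethoxyphenyl with the lowest number of the three, ahead of both halogenated rings. Nothing available accounts for this order.

Open, on these data alone, is how an unsubstituted phenyl or a ring bearing a single methoxy group would compare. Also open, as far as these compounds go, is whether a ring carrying an amine or a carboxylic acid would be tolerated on the carbonyl carbon.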